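Swapping the Ester Group from sec-Butyl to Cyclopropylmethyl

The source may report more compounds than this note shows. Statements on the series, on what has been measured and on what is new or still open speak of the compounds shown alone.

Of the compounds shown here, two built on one shared core have been measured, and they differ only in the group sitting on an oxygen next to a carbonyl group. Compound 1 `COC(=O)C1=C(C)NC(=O)NC1c1ccoc1` carries a methyl there; in an assay on membranes from HeLa cells for displacement of a labelled ligand from adenosine receptor A3 (Homo sapiens), read by scintillation counting, with a stated time of 180 min, tested at 1 uM (on this read-out higher numbers stand for more inhibition at the one concentration tested (going by the name of the read-out) and lower numbers for less inhibition), compound 1 gives 2%. Compound 2 `CCC(C)OC(=O)C1=C(C)NC(=O)NC1c1ccoc1` carries a sec-butyl in that place, and in this assay compound 2 gives 11%. On the numbers shown, compound 2 is separated from compound 1 only by a number 9 percentage points higher from compound 1 to compound 2 (within the scatter), which is within the scatter, so the two readings cannot be told apart.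

Compound 3 `CC1=C(C(=O)OCC2CC2)C(c2ccoc2)NC(=O)N1` has not been measured yet. Its change from compound 2 is cyclopropylmethyl in place of sec-butyl on an oxygen next to a carbonyl group. Among the compounds with values here, the one measured step, a number 9 percentage points higher from compound 1 to compound 2 (within the scatter), also altered the group on that oxygen and stayed within the scatter, even though it traded a one-carbon group for a four-carbon one; the present change keeps the count at four carbons. Nothing measured points to a movement beyond the scatter, so the expected step is a number 1 percentage points lower from compound 2 to compound 3 (within the scatter). Compound 3 is therefore estimated at 10%, with a likely range from 0% to 25%.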

Compound 3, a percentage reported as inhibition, at one concentration (the size of the read-out at that concentration, not a potency): 3%
For compound 3 the middle estimate is 7 percentage points above the measured one, within the range that was stated.
By their numbers in this assay, from the lowest: compounds 1, 3 and 2 (each within the scatter of the next).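

Exchanging sec-butyl for cyclopropylmethyl on an oxygen next to a carbonyl group replaces an open chain with a group holding a three-membered ring of carbon, and this assay records a number 8 percentage points lower from compound 2 to compound 3 (within the scatter), so the compounds give no sign that this ring changes the reading at this position. The same group can also be compared with the methyl of compound 1, where adding cyclopropyl in place of hydrogen on a saturated chain carbon gives a number 1 percentage points higher from compound 1 to compound 3 (within the scatter), which means that methyl, sec-butyl and cyclopropylmethyl cannot be told apart on the shared core at the one concentration tested. No supporting information is available that bears on this result.

The compounds shown leave open whether a benzyl group or a longer chain such as octyl on this oxygen would shift the reading beyond the usual scatter. They also leave open whether an amide in place of the ester, or a change elsewhere on the shared core, would do so.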